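Aryl Replacement at the Pyridine-Like Core and HeLa Cytotoxicity

The source may hold more compounds than are shown below. What is called first, only, known or untested is meant among the compounds shown, and "the series" means these compounds.

Compound 1, `COc1nc(C2CCOCC2)ccc1[C@@H](c1ccccc1)[C@@](O)(CCN(C)C)c1cccc2ccccc12`: 22.5 ug/mL
Compound 2, `COc1nc(-c2ccc(C#N)cc2)ccc1[C@@H](c1ccccc1)[C@@](O)(CCN(C)C)c1cccc2ccccc12`: > 64 ug/mL
Compound 3, `COc1nc(-c2cccc(F)c2)ccc1[C@@H](c1ccccc1)[C@@](O)(CCN(C)C)c1cccc2ccccc12`: 62.8 ug/mL

In a toxicity assay on HeLa cells (Homo sapiens) for cytotoxicity (on this read-out higher numbers stand for lower toxicity in this test and lower numbers for higher toxicity in this test), compound 1 gives 22.5 ug/mL, the lowest of the two numbers reported. For compound 2 the result is a limit, > 64 ug/mL, and the limit of > 64 ug/mL in this assay, at which 1 of the 3 values shown sits, marks that one of the three values sits there. Compound 3 gives 62.8 ug/mL, so a 2.8-fold higher number from compound 1 to compound 3 (0.45 log units; beyond the scatter), and an at least 2.8-fold higher number from compound 1 to compound 2 (0.45 log units; beyond the scatter).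

Compound 4, `COc1ccc(-c2ccc([C@@H](c3ccccc3)[C@@](O)(CCN(C)C)c3cccc4ccccc34)c(OC)n2)cc1`, has not yet been tested in this assay. Its change from compound 1 is 4-methoxyphenyl in place of oxan-4-yl on an aromatic carbon. Both steps from compound 1 that swap the oxan-4-yl for an aromatic ring raised the number by a similar, modest amount, so a comparable rise is expected here: a 2.4-fold higher number from compound 1 to compound 4 (0.39 log units; beyond the scatter). Compound 4 is therefore estimated at 55 ug/mL, within 28 ug/mL to 90 ug/mL.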

Compound 4, half-maximal cytotoxic concentration: > 64 ug/mL
Compound 4: only a limit was reported; the forecaster's own chance of this, stated with the estimate: 40%; at least 1.1-fold (0.06 log units) between middle value and limit.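

In this assay compound 4 gives > 64 ug/mL, which is a limit. With an at least 2.8-fold higher number from compound 1 to compound 4 (0.45 log units; beyond the scatter), all three aromatic replacements of oxan-4-yl shown stand higher than compound 1, and an at least 1.0-fold higher number from compound 3 to compound 4 (0.00 log units; that floor lies within the scatter) does not separate the 4-methoxyphenyl from the 3-fluorophenyl. The step from compound 2 to compound 4 cannot be read, both values being limits: the limit of > 64 ug/mL in this assay, at which 2 of the 4 values shown sit.

The compounds shown leave open how piperidin-4-yl, a non-aromatic ring carrying an amine, or a phenyl bearing a carboxylic acid would read at this position. They also leave open how far the aromatic compounds differ among themselves.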